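A few compounds are considered here, and "the series" means these few. Any claim that something is new, unique, unknown or untested is made for them only; others in the source may bear on it.

In a functional assay on HCT-15 cells (Homo sapiens) for antiproliferative activity, read by sulforhodamine B assay (a higher number here means a weaker inhibitor of growth, a lower number a stronger inhibitor of growth), two compounds with a shared core have been tested so far. Compound 1 `CCCCCCOc1cccc(O)c1C(=O)/C=C/c1ccc(O)cc1` gives > 30000 nM, which is a limit of the assay and not a number. Going by the values given here, compound 2 `O=C(/C=C/c1ccc(O)cc1)c1c(O)cccc1OCC1CCCC1` gives 3410 nM, the only actual number available, so it stands as the sole measured point of reference.

Among the compounds with values here, the one measured step, an at least 8.7-fold lower number from compound 1 to compound 2 (0.94 log units; beyond the scatter), lies beyond the scatter and involves cyclopentyl in place of pentyl at the same place that varies next. Compound 3 `CC(C)COc1cccc(O)c1C(=O)/C=C/c1ccc(O)cc1` has not yet been measured. It differs from compound 2 as follows: isopropyl in place of cyclopentyl on a saturated chain carbon bound to an oxygen on an aromatic ring. In words, this is isopropyl in place of cyclopentyl on a saturated chain carbon bound to an oxygen on an aromatic ring.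

Like compound 1, compound 3 has no ring in this group, and the step of an at least 8.7-fold lower number from compound 1 to compound 2 (0.94 log units; beyond the scatter) shows that losing the ring can cost growth inhibition. A rise in the number is therefore expected, though one step offers only thin guidance on its size. The expected change is a 2.6-fold higher number from compound 2 to compound 3 (0.42 log units; beyond the scatter). For compound 3 the estimated value is 9000 nM, with an expected range from 3000 nM to 30000 nM.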

Compound 3, concentration for 50% growth inhibition: 2600 nM
Beside the measured number, compound 3's estimate is 3.5-fold (0.54 log units) above it, outside the stated range (below it).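

In this assay, the step from the cyclopentyl group to the isopropyl group, a 1.3-fold lower number from compound 2 to compound 3 (0.12 log units; within the scatter), shows that the ring in this group can go without a change beyond the scatter, even though the group entering has fewer carbons and no ring, so the gap seen earlier between compound 1 and compound 2 cannot be read as a simple need for a ring at this place. The open-chain isopropyl group in place of pentyl on the same saturated chain carbon gives an at least 11-fold lower number from compound 1 to compound 3 (1.06 log units; beyond the scatter), so a group without a ring can also stand well apart from compound 1. The value of compound 1 is a limit of the assay and not a number, and the true size of both steps from it stays unknown for that reason: the limit of > 30000 nM in this assay, at which 1 of the 3 values shown sits.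

Compound 2 and compound 3 both carry a branched group at this place and compound 1 an unbranched one, but three compounds cannot tell whether branching or the size of the pentyl group separates them. Also open, on these data alone, is how this place would respond to a shorter unbranched chain such as propyl, to a cyclohexyl ring, or to an amine at the end of the chain.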